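The compounds below may be only part of what the source reports. "The series", "measured", "known", "first", "only" and "open" are said of these compounds alone.

Compound 1 `CCNC(=O)c1cc(Oc2ccc(NC(=O)c3cc4cccnc4n(-c4ccc(Br)cc4F)c3=O)cc2)ccn1` gives 2070 nM in a functional assay on HT-29 cells (Homo sapiens) for antiproliferative activity, read by MTT assay, with a stated time of 72 h; on this read-out lower numbers stand for stronger inhibition and higher numbers for weaker inhibition.
Compound 2 `CCNC(=O)c1cc(Oc2ccc(NC(=O)c3cc4cccnc4n(-c4ccc(C(F)(F)F)cc4Cl)c3=O)cc2)ccn1` gives 4770 nM in this assay.
Compound 3 `CCNC(=O)c1cc(Oc2ccc(NC(=O)c3cc4cccnc4n(-c4ccc(F)c(Cl)c4)c3=O)cc2)ccn1` gives 2600 nM in this assay.

Among these three, compound 1 holds the lowest number. The move to compound 3 is a 1.3-fold higher number from compound 1 to compound 3 (0.10 log units; within the scatter), within the scatter, whereas the move to compound 2 is a 2.3-fold higher number from compound 1 to compound 2 (0.36 log units; beyond the scatter), beyond it. Compound 4 `CCCNC(=O)c1cc(Oc2ccc(NC(=O)c3cc4cccnc4n(-c4ccc(Br)cc4F)c3=O)cc2)ccn1` differs from compound 1 by methyl in place of hydrogen on a saturated chain carbon, two bonds along the chain from an amide-type nitrogen, read one bond further out as ethylamino to propylamino. Within the data shown here, no measured step touches this chain; all three measured steps vary the aryl group on the aromatic nitrogen, so none of them bears on this change. With nothing pointing to a shift, the expected step in this assay for compound 4 is a 1.0-fold higher number from compound 1 to compound 4 (0.01 log units; within the scatter). The estimate for compound 4 is 2100 nM, with a range from 900 nM to 4800 nM.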

Compound 4, half-maximal inhibitory concentration: 2160 nM
Beside the measured number, compound 4's estimate is 1.0-fold (0.01 log units) below it; measured number inside the range.
By their numbers in this assay, from the lowest: compounds 1, 4, 3 and 2 (each within the scatter of the next, the first and the last beyond it).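

Among these compounds, the three earlier compounds vary only the aryl group on the aromatic nitrogen, so compound 4 gives the first reading at this saturated chain carbon. In this assay, the change from ethylamino to propylamino gives a 1.0-fold higher number from compound 1 to compound 4 (0.02 log units; within the scatter), so this pair shows that one added methyl here leaves the two numbers within the scatter of each other. No measurement given here offers an explanation for this result.

On these data alone, whether a longer chain, a hydroxyalkyl chain or an amine in place of propylamino would read the same remains open. Also open, as far as these compounds go, is whether propylamino would behave alike with the aryl groups of compound 2 and compound 3.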